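Notes on a spiro series: ethyl to chloro on the aryl

This account rests on a few compounds, and the source may have more. Where it says the series, first, only, none or still open, it means among the compounds named here.

Measured so far:
compound 1, `N#CC1=C(N)Oc2c(c3nc4ccccc4nc3c3ccccc23)C12C(=O)N(Cc1cnnn1-c1ccc(Cl)c(Cl)c1)c1ccccc12` — a limit only: > 50000 nM
compound 2, `CCc1ccccc1-n1nncc1CN1C(=O)C2(C(C#N)=C(N)Oc3c(N)cc4nc5ccccc5nc4c32)c2ccccc21` — 24600 nM

Both results come from a functional assay on MCF7 cells (Homo sapiens) for antiproliferative activity, read by MTT assay, with a stated time of 48 h; on this read-out higher numbers stand for weaker inhibition and lower numbers for stronger inhibition. Compound 1 reaches only the limit of that read-out, > 50000 nM, and carries no number of its own. Going by the values given here, compound 2 gives 24600 nM in this assay, and that is the only number the series has so far; the other value sits at the limit of > 50000 nM in this assay, at which 1 of the 2 values shown sits, so no step between the two can be drawn, and compound 2 stands alone as the single measured point.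

Compound 3 `N#CC1=C(N)Oc2c(N)cc3nc4ccccc4nc3c2C12C(=O)N(Cc1cnnn1-c1ccccc1Cl)c1ccccc12` has not yet been measured in this assay. It differs from compound 2 in one place: chloro in place of ethyl on an aromatic carbon. Cut one bond further out, the change reads 2-ethylphenyl to 2-chlorophenyl. Among the compounds with values here, no measured pair bears on this exchange, so nothing here shows how this assay answers to it. The step of a 1.1-fold lower number from compound 2 to compound 3 (0.05 log units; within the scatter) is expected to stay within the scatter, in no set direction. Compound 3 is estimated at 22000 nM, with a range from 8000 nM to 50000 nM.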

Compound 3, half-maximal inhibitory concentration: 34400 nM
Beside the measured number, compound 3's estimate is 1.6-fold (0.19 log units) below it, and the stated range covers the measured number.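

Going by these compounds alone, this is the first pair that differs in one place, so the first readable step: in this assay, the exchange of ethyl for chloro on an aromatic carbon, ortho to a large group, gives a 1.4-fold higher number from compound 2 to compound 3 (0.15 log units; within the scatter). At this position, then, 2-ethylphenyl and 2-chlorophenyl cannot be told apart on this read-out, even though the group changes from 2 heavy atoms of carbon to 1 of chlorine and neither group counts any hydrogen-bond donor or acceptor. The pair says nothing about the rest of the series, and the room for reading any further rise in the number at this position is limited by the top of the read-out: the limit of > 50000 nM in this assay, at which 1 of the 3 values shown sits.

As far as these compounds go, whether a methoxy group, an amine or a carboxylic acid on the same aromatic carbon, or a chain longer than ethyl, would carry the number beyond the scatter remains open. Within the data shown here, also open is whether the exchange of ethyl for chloro would read the same on a core other than the one shared by compound 2 and compound 3.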